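The compounds below may be only part of what the source reports. "The series", "measured", "known", "first", "only" and "open" are said of these compounds alone.

Of the compounds shown here, two sharing one core have so far been measured in a functional assay on MCF7 cells (Homo sapiens) for cytotoxicity, read by MTT assay, with a stated time of 48 h; a lower number here means a stronger inhibitor, a higher number a weaker inhibitor. Compound 1 `CCN(CC)C(=S)SC(CC(=O)c1ccccc1)c1ccc(Cl)cc1` gives 120 nM there, while compound 2 `CCN(CC)C(=S)SC(CC(=O)c1ccc(OC)cc1)c1ccc(OC)cc1` gives 800 nM, the higher of the two numbers, and the gap between these two values lies beyond the usual scatter. Compound 3 `CCN(CC)C(=S)SC(CC(=O)c1ccc(OC)cc1)c1ccc(Cl)cc1` has not been measured yet; it differs from compound 2 in one place: chloro in place of methoxy on an aromatic carbon. Because compound 1, which carries the same chloro group, gives 120 nM, a move toward a lower number is expected, estimated at a 3.2-fold lower number from compound 2 to compound 3 (0.51 log units; beyond the scatter). For compound 3 the expected value is 250 nM, within a range from 100 nM to 600 nM.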

Compound 3, half-maximal inhibitory concentration: 16000 nM
Beside the measured number, compound 3's estimate is 64-fold (1.81 log units) below it; the measured number lies above the stated range.
By their numbers in this assay, from the lowest: compound 1; then compound 2; then compound 3.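

Swapping methoxy for chloro here does not help on its own: with methoxy kept on the other aromatic ring, the change gives a 20-fold higher number from compound 2 to compound 3 (1.30 log units; beyond the scatter). The low value of compound 1 therefore does not carry over to every compound with this chloro group, since adding methoxy to the other ring gives a 130-fold higher number from compound 1 to compound 3 (2.12 log units; beyond the scatter). What a group does at this position thus depends on what the other ring carries, at least in these compounds.

Going by these compounds, whether a fluoro group or an amine at this position would behave like chloro or like methoxy remains open. Nothing available explains why the numbers rise so sharply.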